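Alkoxy series, trifluoromethyl added on the second ring

The source may report more compounds than this note shows. Statements on the series, on what has been measured and on what is new or still open speak of the compounds shown alone.

Compound 2 `CCCCOc1ccc(C(CC(=O)O)c2ccccc2)cc1` gives the lowest number of the three measured in a functional assay on HEK293 cells for agonist activity at Free fatty acid receptor 1 (Homo sapiens), read by calcium flux (a higher number here means that more compound is needed for the effect, a lower number that less compound is needed), at 1.2 uM. Compound 1 `CCCOc1ccc(C(CC(=O)O)c2ccccc2)cc1` gives 4.8 uM and compound 3 `C=C(C)CCOc1ccc(C(CC(=O)O)c2ccccc2)cc1` gives 2.71 uM. The steps among them are a 4.0-fold lower number from compound 1 to compound 2 (0.60 log units; beyond the scatter), a 1.8-fold lower number from compound 1 to compound 3 (0.25 log units; within the scatter) and a 2.3-fold higher number from compound 2 to compound 3 (0.35 log units; beyond the scatter); each of these changes only the chain on the oxygen of the aromatic ring.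

Compound 4 `CCCCOc1ccc(C(CC(=O)O)c2cccc(C(F)(F)F)c2)cc1` differs from compound 2 elsewhere: trifluoromethyl in place of hydrogen on an aromatic carbon. Among the measured compounds shown here, none of the measured steps touches the second ring, so none bears directly on this change; the chain steps only show that changes have so far moved this assay by modest amounts. For the measured compounds named here, with no step of this kind measured, the expected step of no change at the digits printed from compound 2 to compound 4 (within the scatter) in this assay is none beyond the scatter, with a wide allowance either way. Compound 4 is therefore estimated at 1.2 uM, within 0.3 uM to 4.5 uM.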

Compound 4, concentration for half-maximal effect: 2.84 uM
Compound 4: the middle estimate sits 2.4-fold (0.37 log units) below what was measured; the measured number falls inside the stated range.
By their numbers in this assay, from the lowest: compound 2; then compounds 3, 4 and 1 (each within the scatter of the next).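

The second ring now proves to bear on this assay: trifluoromethyl in place of hydrogen on an aromatic carbon, meta to a large group, gives a 2.4-fold higher number from compound 2 to compound 4 (0.37 log units; beyond the scatter), whereas every earlier step changed only the chain on the oxygen. This modest step, beyond the scatter, runs upward, so on the chain of compound 2 this substitution at this position does not lower the number. No measurement at hand accounts for the rise.

Going by these compounds, whether the rise belongs to trifluoromethyl itself or to this position stays open; a methyl or a chlorine on the same carbon, or trifluoromethyl elsewhere on that ring, would separate the two. Also open, on these data alone, is whether the step carries over to the chain of compound 1, the chain of compound 3 or a longer chain.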